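Benzyl to cyclohexyl on the amine of compound 2

The source may hold more compounds than are shown below. What is called first, only, known or untested is meant among the compounds shown, and "the series" means these compounds.

Measured compounds:
compound 1, `CC1(C)CC(=O)c2ccc(NCc3ccccc3)nc2C1`: 45000 nM
compound 2, `CC1(C)CC(=O)c2cc(C#N)c(NCc3ccccc3)nc2C1`: 2500 nM

For the measured compounds named here, of the two measured compounds, compound 2 stands with the lower number in an in vitro functional assay on cells for antagonist activity at metabotropic glutamate receptor 1 (Rattus norvegicus), read by inositol phosphate accumulation (a higher number here means a weaker inhibitor, a lower number a stronger inhibitor), the only step to it being an 18-fold lower number from compound 1 to compound 2 (1.26 log units; beyond the scatter). Compound 3, `CC1(C)CC(=O)c2cc(C#N)c(NC3CCCCC3)nc2C1`, differs from compound 2 in one place: cyclohexyl in place of benzyl on a nitrogen on an aromatic ring. Going by the values given here, none of the measured steps concerns this place; the single step known, from compound 1 to compound 2, changed a substituent on the aromatic ring, not the group on the nitrogen, and so gives no guide to the direction of this change. With nothing in the data bearing on it, the step of a 1.3-fold lower number from compound 2 to compound 3 (0.10 log units; within the scatter) is expected to be small, within or near the scatter, and compound 3 is therefore estimated at 2000 nM in this assay, with a wide range from 400 nM to 10000 nM reflecting the absence of any comparable step.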

Compound 3, half-maximal inhibitory concentration: 4000 nM
Compound 3: middle estimate off by 2.0-fold (0.30 log units), on the low side; the range from low to high includes it.
By their numbers in this assay, from the lowest: compounds 2 and 3 (each within the scatter of the next); then compound 1.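

In this assay, for the compounds shown here, the step of a 1.6-fold higher number from compound 2 to compound 3 (0.20 log units; within the scatter) gives the first reading at the group on the nitrogen, and at this place benzyl and cyclohexyl cannot be told apart. A six-membered aromatic ring of carbon only gives way here to a six-membered non-aromatic one, and the number stays within the scatter, so the aromatic ring of benzyl is not needed to hold the level of compound 2. No measurement at hand bears on why the two groups read alike.

What the compounds shown leave open is whether a group on the nitrogen with no ring at all, such as an isopropyl group or a longer alkyl chain, would read the same. Also open, from the compounds shown here alone, is how a benzyl ring carrying a fluorine or a methoxy group would compare.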